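Removing the Indole Benzyl Group in a Thiazole Urea Series

This account rests on a few compounds, and the source may have more. Where it says the series, first, only, none or still open, it means among the compounds named here.

Measured so far:
- compound 1, `CC1CCN(Cc2ccc3nc(NC(=O)N/N=C/c4cn(Cc5cccc(Cl)c5)c5ccccc45)sc3c2)CC1`: 2110 nM
- compound 2, `CN(C)Cc1ccc2nc(NC(=O)N/N=C/c3cn(Cc4ccccc4)c4ccccc34)sc2c1`: 1340 nM
- compound 3, `CCN(CC)Cc1ccc2nc(NC(=O)N/N=C/c3cn(Cc4cccc(Cl)c4)c4ccccc34)sc2c1`: 2050 nM

All three compounds were tested in a functional assay on MDA-MB-231 cells (Homo sapiens) for cytotoxicity, read by MTT assay, with a stated time of 72 h; a lower number here means a stronger inhibitor, a higher number a weaker inhibitor. Compound 1 gives the highest number of the three, but its gaps to compound 3 and to compound 2 both lie within the scatter, so no ordering among them can be drawn. Going by the values given here, the one measured step, a 1.0-fold lower number from compound 1 to compound 3 (0.01 log units; within the scatter), changes only the amine on the saturated chain carbon and leaves the number essentially unchanged.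

Compound 4, `CC1CCN(Cc2ccc3nc(NC(=O)N/N=C/c4c[nH]c5ccccc45)sc3c2)CC1`, differs from compound 1 at a different place: hydrogen in place of 3-chlorobenzyl on an aromatic nitrogen. Among the compounds with values here, no measured step touches this position, so there is no direct guide. Compound 2 carries a benzyl group without chlorine at the same nitrogen and gives 1340 nM, yet it also differs in the amine, so only its value can be noted. Without a bearing step, the expected direction is uncertain; a modest rise in the number is estimated, a 1.9-fold higher number from compound 1 to compound 4 (0.28 log units; within the scatter). Compound 4 is therefore expected to give about 4000 nM, within a range from 1500 nM to 12000 nM.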

Compound 4, half-maximal inhibitory concentration: 2460 nM
Compound 4: the middle estimate sits 1.6-fold (0.21 log units) above what was measured; the range from low to high includes it.
By their numbers in this assay, from the lowest: compounds 2, 3, 1 and 4 (each within the scatter of the next).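

In this assay, going by these compounds alone, replacing the 3-chlorobenzyl group on the aromatic nitrogen with hydrogen gives a 1.2-fold higher number from compound 1 to compound 4 (0.07 log units; within the scatter), the first direct reading at this position. A group of eight heavy atoms, including a six-membered aromatic ring, can therefore be removed from compound 1 without moving the number beyond the scatter, so this pair shows no dependence of the cytotoxicity read-out on the 3-chlorobenzyl group. No measurement at hand explains this outcome.

Hydrogen on this nitrogen appears only alongside the 4-methylpiperidin-1-yl amine, so it remains open whether the same holds with the diethylamino or dimethylamino amines. As far as these compounds go, it is also open how a different group on the same nitrogen, such as a methyl group or a longer chain ending in a carboxylic acid, would behave.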